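This account rests on a few compounds, and the source may have more. Where it says the series, first, only, none or still open, it means among the compounds named here.

Measured compounds:
- compound 1 `CCN(CC)c1cc2[nH]c(C3CCCCC3)nc2cc1NC(=O)c1ccc(N(C)C)cc1`: in an ADME assay on Vero cells (Chlorocebus sabaeus) for cytotoxicity, read by resazurin assay, with a stated time of 3 days (on this read-out higher numbers stand for weaker inhibition and lower numbers for stronger inhibition), compound 1 gives "not determined" (no result reported).
- compound 2 `CCN(CC)c1cc2[nH]c(C3CCCCC3)nc2cc1NC(=O)c1ccc(F)cc1`: in this assay compound 2 gives > 100 ug/mL, a limit of the assay rather than a number.
- compound 3 `CCc1ccc(C(=O)Nc2cc3nc(C4CCCCC4)[nH]c3cc2N(C)C)cc1`: in this assay compound 3 gives > 100 ug/mL, again a limit of the assay rather than a number.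

Compound 3 therefore stands nowhere definite on the numbers shown: its own entry is a limit, one further entry is the same limit, and the entry for compound 1 holds no single number. For the measured compounds named here, the only point of reference is the limit of > 100 ug/mL in this assay, at which 2 of the 3 values shown sit; no step between measured compounds can be read from these entries.

The next compound, compound 4 `CCc1ccc(C(=O)Nc2cc3nc(C4CCCCC4)[nH]c3cc2N(CC)CC)cc1`, differs from compound 3 by diethylamino in place of dimethylamino on an aromatic carbon. With both measured values sitting at the limit, no step beyond the usual scatter is expected in this assay in either direction. The expected step from compound 3 to compound 4 is a number no higher from compound 3 to compound 4 (the limit leaves the size open). Compound 4 is estimated at 100 ug/mL, within 50 ug/mL to 200 ug/mL, and most probably again reported only as a limit.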

Compound 4, half-maximal inhibitory concentration: > 100 ug/mL
Compound 4 was reported as a limit; the forecaster's own chance of this, stated with the estimate: 75%; the middle value lies on the limit itself.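

Compound 4 gives > 100 ug/mL in this assay, a limit of the assay and not a number. No step from compound 2 or compound 3 to compound 4 can be read: the limit of > 100 ug/mL in this assay, at which 3 of the 4 values shown sit.

The compounds shown leave open where the actual half-maximal inhibitory concentrations of compound 2, compound 3 and compound 4 lie.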